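The source may report more compounds than this note shows. Statements on the series, on what has been measured and on what is new or still open speak of the compounds shown alone.

Compound 1 `CC(C)(C)c1ccc(S(=O)(=O)Nc2ccc(Cl)cc2-c2ncccc2N)cc1`: 95 nM
Compound 2 `CNc1ncc(O)c(-c2cc(Cl)ccc2NS(=O)(=O)c2ccc(C(C)(C)C)cc2)n1`: 27 nM

Of the compounds shown here, two have been measured in a functional assay on isolated protein for antagonist activity at C-C chemokine receptor type 9 (Homo sapiens), read by calcium flux, with a stated time of 10 min (a lower number here means a stronger inhibitor, a higher number a weaker inhibitor), and compound 2 gives the lower number, 27 nM, while compound 1 gives 95 nM; the gap is a 3.5-fold lower number from compound 1 to compound 2 (0.55 log units; beyond the scatter). For the measured compounds named here, the only change between them was the ring group hanging from the shared core, so that group is the one place where the numbers have so far responded.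

Compound 3 `CN(C)c1ncnc(-c2cc(Cl)ccc2NS(=O)(=O)c2ccc(C(C)(C)C)cc2)c1O` alters the same ring group again: a group of 10 heavy atoms (6 carbon, 3 nitrogen, 1 oxygen; one six-membered aromatic ring with 2 hetero atoms) in place of a group of 9 heavy atoms (5 carbon, 3 nitrogen, 1 oxygen; one six-membered aromatic ring with 2 hetero atoms), on an aromatic carbon. The group that leaves carries 2 hydrogen-bond donors and 4 hydrogen-bond acceptors; the group that enters carries 1 hydrogen-bond donor and 4 hydrogen-bond acceptors. It sits on an aromatic carbon of a six-membered aromatic ring of carbon only, ortho to a large group and meta to a chloro group.

Going by the values given here, the one step that bears on this, a 3.5-fold lower number from compound 1 to compound 2 (0.55 log units; beyond the scatter), shows the ring group can shift the number modestly. Compound 3 keeps the hydroxyl-bearing ring, and its step is expected to be a 1.5-fold higher number from compound 2 to compound 3 (0.17 log units; within the scatter). The estimate for compound 3 is 40 nM, ranging from 12 nM to 130 nM.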

Compound 3, half-maximal inhibitory concentration: 9 nM
Compound 3: middle estimate off by 4.4-fold (0.65 log units), on the high side, and the stated range ends above it.
By their numbers in this assay, from the lowest: compound 3; then compound 2; then compound 1.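

In this assay, the result shows that this position had more room than the first step revealed: a further change to the ring group gives a 3.0-fold lower number from compound 2 to compound 3 (0.48 log units; beyond the scatter), and the total change across the series is an 11-fold lower number from compound 1 to compound 3 (1.02 log units; beyond the scatter), so compound 3 has the lowest number of the three. For the compounds shown here, the group that enters carries 1 hydrogen-bond donor where the group that leaves carries 2, and it has one more carbon, so at this position having fewer donors did not come with a higher number, and across these three compounds the number falls as the ring group gains heavy atoms, with no compound going against that trend. No supporting evidence on why the number moved is available here.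

The step from compound 2 to compound 3 changes more than one feature of the ring group at once, so the contribution of each feature remains unresolved. Going by these compounds, it also remains open how this position would respond to a larger amine such as a diethylamino group, or to a carboxylic acid on the ring.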